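The source may hold more compounds than are shown below. What is called first, only, known or untested is meant among the compounds shown, and "the series" means these compounds.

Two compounds in this small series share a core and differ only in what sits on an amide-type nitrogen. Compound 1 `COc1ccc(NC(=O)/C(C#N)=C/c2cc(O)c(O)c([N+](=O)[O-])c2)cc1` carries 4-methoxyphenyl there, and in a functional assay on BGC-823 cells (Homo sapiens) for antiproliferative activity, read by MTT assay (on this read-out lower numbers stand for stronger inhibition and higher numbers for weaker inhibition), compound 1 gives 45.4 ug/mL. Among the measured compounds shown here, compound 2 `N#C/C(=C\c1cc(O)c(O)c([N+](=O)[O-])c1)C(=O)Nc1ccccc1Cl` carries 2-chlorophenyl instead, and in this assay compound 2 gives 10.5 ug/mL, the lowest of the two numbers measured so far; the swap brought a 4.3-fold lower number from compound 1 to compound 2 (0.64 log units; beyond the scatter). Compound 3 `N#C/C(=C\c1cc(O)c(O)c([N+](=O)[O-])c1)C(N)=O` takes the change a step further: hydrogen in place of 2-chlorophenyl on an amide-type nitrogen. For the measured compounds named here, the only measured step that bears on this is the one between compound 1 and compound 2, at the same amide-type nitrogen; it shows that exchanging one six-membered aromatic ring of carbon only for another shifts the number modestly, yet it does not show what removing that ring altogether does. A step at least as large as that one seems reasonable to expect, and since compound 2 already holds the lowest number, a higher number for compound 3 appears somewhat more likely than a lower one. For compound 3 the number is therefore estimated at 28 ug/mL, within a range of 8 ug/mL to 90 ug/mL, which means an expected step of a 2.7-fold higher number from compound 2 to compound 3 (0.43 log units; beyond the scatter).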

Compound 3, half-maximal inhibitory concentration: > 100 ug/mL
Compound 3: a limit, no number (the forecaster's own chance of this, stated with the estimate: 10%); at least 3.5-fold (0.55 log units) between middle value and limit.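

Compound 3 gives a limit of the assay in this assay rather than a number: the limit of > 100 ug/mL in this assay, at which 1 of the 3 values shown sits. Even so, the steps can still be read, and taking the aromatic ring away from the amide-type nitrogen gives an at least 9.5-fold higher number from compound 2 to compound 3 (0.97 log units; beyond the scatter), while hydrogen in place of 4-methoxyphenyl gives an at least 2.2-fold higher number from compound 1 to compound 3 (0.34 log units; beyond the scatter). The earlier pair showed only that one aromatic ring and another can differ at this nitrogen; now it appears that, among these three compounds, both that carry a six-membered aromatic ring of carbon only there have lower numbers than the compound with hydrogen alone, and none of the three goes against this.

On these data alone, what stays open is whether the ring itself is needed or whether some other group on the same nitrogen, such as a methyl, a longer alkyl chain or a saturated cyclohexyl ring, would also give a lower number. Plain phenyl at this position would also bear on how much the chlorine atom and the methoxy group each contribute, which these compounds cannot separate from the ring.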